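The compounds below may be only part of what the source reports. "The series", "measured", "known", "first", "only" and "open" are said of these compounds alone.

Working notes on the series. In a functional assay on HL-60 cells (Homo sapiens), read by calcium flux (on this read-out lower numbers stand for an effect already at smaller amounts and higher numbers for an effect only at larger amounts of compound), compound 1 `CCc1cc(Cc2cccc(OC)c2)c(=O)n(CC(=O)Nc2ccc(I)cc2)n1` gives only a limit, > 50000 nM. Compound 2 `COc1ccc(Cc2cc(-c3ccc(Cl)cc3)nn(CC(=O)Nc3ccc(Br)cc3)c2=O)cc1` likewise gives a limit, > 50000 nM. Compound 3 `COc1ccc(Cc2cc(-c3ccc(C)cc3)nn(CC(=O)Nc3ccc(Br)cc3)c2=O)cc1` also gives a limit, > 50000 nM. The step that the two limits leave unreadable from compound 2 to compound 3 is therefore not readable, and all three values sit at the limit of > 50000 nM in this assay, at which 3 of the 3 values shown sit. Compound 4 `COc1ccc(Cc2cc(Cc3ccccc3)nn(CC(=O)Nc3ccc(Br)cc3)c2=O)cc1` differs from compound 3 by benzyl in place of 4-methylphenyl on an aromatic carbon. Among the compounds with values here, no measured step bears on this exchange, and the values of compounds 1 to 3 offer no foothold beyond the limit itself. For compound 4 an outcome at the limit again is expected, the estimated step being a step that the limit leaves unreadable from compound 3 to compound 4. The expected value for compound 4 is 80000 nM, ranging from 20000 nM to 300000 nM.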

Compound 4, half-maximal effective concentration: > 50000 nM
Compound 4 ended at the assay's limit; the forecaster's own chance of this, stated with the estimate: 80%; the middle value is on the limit's open side.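

Compound 4 also gives only a limit, > 50000 nM, so neither step to it from compound 2 or compound 3 can be read: the limit of > 50000 nM in this assay, at which 4 of the 4 values shown sit. The compounds shown leave open whether any change on the shared core gives a measurable value in this assay.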